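The compounds below may be only part of what the source reports. "The series", "measured", "known", "first", "only" and "open" are said of these compounds alone.

Of the compounds shown here, two have so far been measured in a functional assay on A549 cells (Homo sapiens) for cytotoxicity, read by CCK-8 assay, with a stated time of 24 h; a lower number here means a stronger inhibitor, a higher number a weaker inhibitor. Compound 1, `C/C(=C\c1cc(-c2ccc(F)nc2)co1)C(N)=O`, reaches only the assay limit, giving > 50000 nM as a limit rather than a number. Compound 2, `C/C(=C\c1cc(-c2ccccc2)cs1)C(N)=O`, likewise reaches the assay limit and gives > 50000 nM, again a limit and not a number. Both measured compounds therefore stand at the same point, as summarised by the limit of > 50000 nM in this assay, at which 2 of the 2 values shown sit. Compound 3, `C/C(=C\c1cc(-c2ccc(C)cc2)cs1)C(N)=O`, differs from compound 2 by methyl in place of hydrogen on an aromatic carbon. No measured step joins any two of these compounds, so the size of this change cannot be read from measured values. The expected step in this assay is a step that the limit leaves unreadable from compound 2 to compound 3, which means no change beyond the usual scatter. Compound 3 is estimated at 60000 nM, within a range from 20000 nM to 200000 nM, and is expected most likely to reach only the assay limit once more.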

Compound 3, half-maximal inhibitory concentration: > 50000 nM
Compound 3: a limit, no number; the forecaster's own chance of this, stated with the estimate: 80%; the middle value lies beyond the limit too.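

Going by these compounds alone, compound 2 and compound 3 both give a limit rather than a number in this assay, and no step between them can be read. The compounds shown leave open whether methyl in place of hydrogen on an aromatic carbon shifts the value at all, and whether any of them would give a number in this assay.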